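The source may hold more compounds than are shown below. What is called first, only, known or untested is meant among the compounds shown, and "the series" means these compounds.

Measured compounds in an ADME assay on HFF cells (Homo sapiens) for cytotoxicity, read by MTT assay, with a stated time of 72 h; a higher number here means a weaker inhibitor, a lower number a stronger inhibitor:
- compound 1, `O=C1O[C@H]([C@@H](O)Cn2cc(-c3cccc(O)c3)nn2)C(OCc2ccccc2)=C1OCc1ccccc1`: 39000 nM
- compound 2, `O=C1O/C(=C\Cn2cc(-c3cccc(O)c3)nn2)C(OCc2ccccc2)=C1OCc1ccccc1`: 42600 nM

For the measured compounds named here, compound 1 is one of only two compounds measured, and its nearest neighbour in this assay, compound 2, gives a number within the scatter of it, so the two are read as the same. Compound 3, `Cc1ccc(S(=O)(=O)NCc2cn(C[C@H](O)[C@H]3OC(=O)C(OCc4ccccc4)=C3OCc3ccccc3)nn2)cc1`, is not yet measured in this assay. It differs from compound 1 as follows: (((4-methylphenyl)sulfonyl)amino)methyl in place of 3-hydroxyphenyl on an aromatic carbon. Going by the values given here, no step between measured compounds is available for a change of this kind, and the two numbers known give no basis for a shift in either direction. The expectation is therefore a step from compound 1 of no size beyond the scatter, a 1.0-fold higher number from compound 1 to compound 3 (0.01 log units; within the scatter). In this assay compound 3 is estimated at 40000 nM, within a range of 15000 nM to 110000 nM.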

Compound 3, half-maximal inhibitory concentration: 50 nM
Estimate against measurement, compound 3: 800-fold (2.90 log units) above; the whole stated range lies above it.
By their numbers in this assay, from the lowest: compound 3; then compounds 1 and 2 (each within the scatter of the next).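

In this assay, for the compounds shown here, the position on the aromatic carbon of the five-membered aromatic ring with 3 nitrogen proves highly sensitive to substitution: (((4-methylphenyl)sulfonyl)amino)methyl in place of 3-hydroxyphenyl gives a 780-fold lower number from compound 1 to compound 3 (2.89 log units; beyond the scatter), a change the earlier compounds, which both carry 3-hydroxyphenyl, could not reveal. Both groups hold one six-membered aromatic ring of carbon only, so the presence of such a ring alone does not account for the difference between compound 1 and compound 3. No measurement shown here bears on the reason for this step.

Which part of the entering group goes with the step remains open. An unsubstituted phenylsulfonylaminomethyl group, a benzylamine or a benzamide at this position would help separate the contributions of the methyl, the sulfonyl and the nitrogen link.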